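The source may report more compounds than this note shows. Statements on the series, on what has been measured and on what is new or still open speak of the compounds shown alone.

Measured so far:
- compound 1 `Clc1ccc(-c2csc(N/N=C/c3cccs3)n2)cc1`: 97%
- compound 2 `Cc1ccc(-c2csc(N/N=C/c3ccc(Cl)cc3Cl)n2)cc1`: 95.1%

Both compounds were tested in a functional assay, read by spectrophotometry, with a stated time of 15 min, tested at 100 ug/mL; on this read-out higher numbers stand for a stronger effect at the one concentration tested and lower numbers for a weaker effect. On the numbers shown, compound 1 carries the larger of the two values, with compound 2 the nearest; the gap between them falls within the usual scatter of such measurements, so the two cannot be told apart. Compound 1 therefore stands near the top of what this read-out can report, and there is little room for any step upward from it.

The compound now in question is compound 3 `Fc1ccc(-c2csc(N/N=C/c3cccs3)n2)cc1`. It keeps the whole of compound 1 apart from one change: fluoro in place of chloro on an aromatic carbon. Among the measured compounds shown here, nothing among the measured compounds shows what such a swap does, since no pair of them differs in just this one place.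

Given that, the expectation is for compound 3 to stay close to compound 1 in this assay, with the step of a number 7 percentage points lower from compound 1 to compound 3 (within the scatter) expected to be small and downward if anything, not beyond the scatter. Compound 3 is estimated at 90%, within a range from 75% to 99%.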

Compound 3, a percentage reported as inhibition, at one concentration (the size of the read-out at that concentration, not a potency): 97%
Compound 3: the middle estimate sits 7 percentage points below what was measured; the range from low to high includes it.
By their numbers in this assay, from the lowest: compounds 2, 1 and 3 (each within the scatter of the next).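

In this assay, among the compounds shown here, putting fluoro in place of chloro on an aromatic carbon, para to a large group, gives no change at the digits printed from compound 1 to compound 3 (within the scatter), and this is the first comparison here that isolates a single place in the structure. It shows that at this position, with the rest of compound 1 kept intact, either of these two groups is compatible with a reading near the top of the scale, so the chloro group is not specifically required to keep the effect at this one concentration. Still, a single-concentration reading this close to the top of the scale is not a potency, and nothing available explains why the two groups read alike.

Going by these compounds, it remains open whether a quite different group at this position, such as an amine or a carboxylic acid, would keep the reading this high or bring it down clearly. On these data alone, it is also open whether compound 1 and compound 3 would separate at lower concentrations, where the read-out would have room to show a difference between them.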